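The source may hold more compounds than are shown below. What is called first, only, known or untested is meant among the compounds shown, and "the series" means these compounds.

Compound 1 `COc1ccc(Cn2c(=O)n(C3OC(CO)[C@@H](O)[C@H]3O)c3nc(N)nc(O)c32)cc1` gives 14% in a functional assay on the whole organism with Mus musculus as the target; on this read-out lower numbers stand for smaller maximal responses and higher numbers for larger maximal responses.
Compound 2 `CCn1c(=O)n(C2OC(CO)[C@@H](O)[C@H]2O)c2nc(N)nc(O)c21` gives 82% in this assay.

Compound 2 stands highest of the two measured compounds, with compound 1 the nearest. Compound 3 `CCCCn1c(=O)n(C2OC(CO)[C@@H](O)[C@H]2O)c2nc(N)nc(O)c21` differs from compound 2 by ethyl in place of hydrogen on a saturated chain carbon, two bonds along the chain from an aromatic nitrogen. For the measured compounds named here, the only measured step bearing on this chain is a number 68 percentage points higher from compound 1 to compound 2 (beyond the scatter), where a smaller group at the same carbon went with the larger response. Extending the chain the other way, an opposite shift of moderate size is therefore expected, namely a number 22 percentage points lower from compound 2 to compound 3 (beyond the scatter). Compound 3 is expected to reach about 60%, within a range from 30% to 85%.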

Compound 3, largest response reached (reported as maximal response), in percent of the reference or control that the assay uses: 70%
Beside the measured number, compound 3's estimate is 10 percentage points below it; the range from low to high includes it.
By their numbers in this assay, from the lowest: compound 1; then compound 3; then compound 2.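

Going from ethyl to butyl on this chain, the response falls only modestly in this assay, with a number 12 percentage points lower from compound 2 to compound 3 (beyond the scatter) as the step. Set against the 4-methoxyphenyl group, the straight chain keeps most of the response, as a number 56 percentage points higher from compound 1 to compound 3 (beyond the scatter) shows, so adding chain length alone does not reproduce the low response of compound 1. Nothing available here explains why these groups differ. Still open, on these data alone, is whether a longer chain such as octyl would lower the response further, and what an amine or a carboxylic acid at the chain end would do.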